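An Isomeric Chain Change in Compound 1

The source may hold more compounds than are shown below. What is called first, only, known or untested is meant among the compounds shown, and "the series" means these compounds.

In a functional assay on DU-145 cells (Homo sapiens) for antiproliferative activity, read by MTT assay, with a stated time of 48 h (a lower number here means a stronger inhibitor, a higher number a weaker inhibitor), compound 1 `COc1cc(C(=O)/C=C/c2ccc(OCCCC(=O)NCCCNCCCCN)cc2)cc(OC)c1OC` gives > 100000 nM, which is a limit of the assay and not a number. The same limit is described by the limit of > 100000 nM in this assay, at which 1 of the 2 values shown sits. A second compound, compound 2 `COc1ccc(/C=C/C(=O)c2cc(OC)c(OC)c(OC)c2)cc1OCCCC(=O)NCCCCN(CCCN)CCCCNCCCN`, has a measured value of 84900 nM in this assay.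

Compound 3 `COc1cc(C(=O)/C=C/c2ccc(OCCCC(=O)NCCCCNCCCN)cc2)cc(OC)c1OC` contains the same atoms as compound 1, joined differently. In compound 3, ((3-aminopropyl)amino)methyl stands in place of (4-aminobutyl)amino on a saturated chain carbon, three bonds along the chain from an amide-type nitrogen: ((3-aminopropyl)amino)methyl in place of (4-aminobutyl)amino on a saturated chain carbon, three bonds along the chain from an amide-type nitrogen. Among the compounds with values here, no measured pair in this small set isolates such a change, so its effect cannot be sized directly. No step beyond the usual scatter is therefore expected in this assay, and compound 3 may well report a limit too. With compound 2 measured at 84900 nM, a value in the same weak region is expected, and the expected move is an at least 1.0-fold lower number from compound 1 to compound 3 (0.02 log units; that floor lies within the scatter). For compound 3, the estimated value is 95000 nM, with an expected range from 40000 nM to 200000 nM.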

Compound 3, half-maximal inhibitory concentration: 54800 nM
The estimate for compound 3 lay 1.7-fold (0.24 log units) above the measured number; the range from low to high includes it.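

In this assay compound 1 gives > 100000 nM, which is a limit of the assay and not a number. The pair offers the first direct view of this position, on a saturated chain carbon, three bonds along the chain from an amide-type nitrogen: ((3-aminopropyl)amino)methyl replaces (4-aminobutyl)amino with the same count of heavy atoms, hydrogen-bond donors and hydrogen-bond acceptors, and the change reads as an at least 1.8-fold lower number from compound 1 to compound 3 (0.26 log units; that floor lies within the scatter). This step is only a floor, and it cannot be placed beyond the usual scatter because one end of the pair is not a number: the limit of > 100000 nM in this assay, at which 1 of the 3 values shown sits.

On these data alone, the true distance between compound 1 and compound 3 therefore stays open, and a single isomeric pair cannot show whether the same rearrangement would have a similar effect on another chain. As far as these compounds go, it also remains open how a longer polyamine chain, or a carboxylic acid in place of ((3-aminopropyl)amino)methyl on this saturated chain carbon, would read in this assay.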